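Dithiocarbamate Amine Swap on a Chromone Core

The source may hold more compounds than are shown below. What is called first, only, known or untested is meant among the compounds shown, and "the series" means these compounds.

In a functional assay on LM7 cells (Homo sapiens) for antiproliferative activity, read by MTT assay, with a stated time of 72 h (a lower number here means a stronger inhibitor, a higher number a weaker inhibitor), compound 1 `CCOC(=O)c1cc(=O)c2cc(CSC(=S)N(C(C)C)C(C)C)ccc2o1` gives > 25000 nM, which is a limit of the measurement rather than a number. Compound 2 `COc1ccc2occ(CSC(=S)N3CCOCC3)c(=O)c2c1` likewise gives only a limit, > 40000 nM, in this assay. Among the compounds with values here, compound 1 therefore stands on a limit, as does the one companion value: the limit of > 25000 nM in this assay, at which 1 of the 2 values shown sits, and (the limit of > 40000 nM in this assay, at which 1 of the 2 values shown sits). Compound 3 `CCOC(=O)c1cc(=O)c2cc(CSC(=S)N3CCCC3)ccc2o1` carries pyrrolidin-1-yl in place of diisopropylamino on a thiocarbonyl carbon. Within the data shown here, with no measured step available, the step from compound 1 to compound 3 is expected to be a step that the limit leaves unreadable from compound 1 to compound 3, none beyond the usual scatter. Compound 3 is estimated at 30000 nM in this assay, with a range from 10000 nM to 100000 nM.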

Compound 3, half-maximal inhibitory concentration: 18000 nM
The estimate for compound 3 lay 1.7-fold (0.22 log units) above the measured number, and the stated range covers the measured number.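

Within the data shown here, with pyrrolidin-1-yl on the thiocarbonyl carbon, compound 3 gives 18000 nM in this assay, the first value here that is a number and not a limit. The swap is an at least 1.3-fold lower number from compound 1 to compound 3 (0.14 log units; that floor lies within the scatter), so it is bounded from one side only, and that bound does not separate the two amines. Compound 1 itself remains a limit: the limit of > 25000 nM in this assay, at which 1 of the 3 values shown sits.

As far as these compounds go, the true size of this step stays open. Also open, from the compounds shown here alone, is whether piperidin-1-yl or dimethylamino on the same thiocarbonyl carbon would read differently from pyrrolidin-1-yl in this assay.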